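Heptyl in Place of Methoxy on a Sulfonamide Aryl Ring

This account rests on a few compounds, and the source may have more. Where it says the series, first, only, none or still open, it means among the compounds named here.

Of the compounds shown here, two sharing one core have been tested in a functional assay on MCF7 cells (Homo sapiens) for antiproliferative activity, read by sulforhodamine B assay, with a stated time of 48 h; a higher number here means a weaker inhibitor, a lower number a stronger inhibitor. Compound 1 `CCc1ccccc1NS(=O)(=O)c1ccc(N2CCNC2=O)cc1` gives 350 nM in this assay. Compound 2 `COc1ccc(NS(=O)(=O)c2ccc(N3CCNC3=O)cc2)cc1` reaches the limit of this assay, > 1000 nM, so for compound 2 only a limit and no exact number is known (the limit of > 1000 nM in this assay, at which 1 of the 2 values shown sits). Going by the values given here, the one measured step, an at least 2.8-fold higher number from compound 1 to compound 2 (0.45 log units; beyond the scatter), shows that exchanging the aryl group on the sulfonamide nitrogen can shift potency. Compound 3 `CCCCCCCc1ccc(NS(=O)(=O)c2ccc(N3CCNC3=O)cc2)cc1` differs from compound 2 by heptyl in place of methoxy on an aromatic carbon. Among the compounds with values here, no measured step touches this position or this kind of group, so the single known step bears on it only loosely and gives no clear direction. Compound 3 is therefore expected to give an estimated 1500 nM, with a range from 400 nM to 6000 nM. The expected step that the limit leaves unreadable from compound 2 to compound 3 is taken to lie within the scatter.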

Compound 3, half-maximal inhibitory concentration: > 1000 nM
Compound 3: only a limit was reported; the forecaster's own chance of this, stated with the estimate: 55%; the middle value lies beyond the limit too.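

No step can be read between compound 2 and compound 3, because both results are limits and not numbers: the limit of > 1000 nM in this assay, at which 2 of the 3 values shown sit.

The compounds shown leave open whether heptyl in place of methoxy on an aromatic carbon changes potency in this assay, and in which direction.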